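This account rests on a few compounds, and the source may have more. Where it says the series, first, only, none or still open, it means among the compounds named here.

Series on the shared core, measured in a functional assay on HEK293 cells for agonist activity at D(4) dopamine receptor (Homo sapiens), read by FLIPR; on this read-out lower numbers stand for an effect already at smaller amounts and higher numbers for an effect only at larger amounts of compound:
- compound 1, `CCc1cccc(NC(=O)CN2CCC(c3cccc[n+]3[O-])CC2)c1`: 95 nM
- compound 2, `Cc1cc(NC(=O)CN2CCC(c3cccc[n+]3[O-])CC2)ccc1F`: 18 nM
- compound 3, `O=C(CN1CCC(c2cccc[n+]2[O-])CC1)Nc1ccc(F)cc1F`: 103 nM

Compound 1 stands second highest of the three numbers; compound 3 sits within the scatter of it, while compound 2 lies beyond it, with a 5.3-fold lower number from compound 1 to compound 2 (0.72 log units; beyond the scatter). Compound 4, `O=C(CN1CCC(c2cccc[n+]2[O-])CC1)Nc1cccc(-c2ccccc2)c1`, differs from compound 1 by phenyl in place of ethyl on an aromatic carbon. For the measured compounds named here, none of the measured steps adds a phenyl; each exchanges the whole substitution pattern of the aryl ring, and they span a 1.1-fold higher number from compound 1 to compound 3 (0.04 log units; within the scatter) and a 5.7-fold higher number from compound 2 to compound 3 (0.76 log units; beyond the scatter). They bear on the new step only loosely. A change in this assay of modest size at most is expected, direction uncertain, that is a 1.6-fold higher number from compound 1 to compound 4 (0.20 log units; within the scatter). Compound 4 is therefore estimated at 150 nM, with a range from 40 nM to 500 nM.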

Compound 4, half-maximal effective concentration: 360 nM
For compound 4 the middle estimate is 2.4-fold (0.38 log units) below the measured one; the range from low to high includes it.
By their numbers in this assay, from the lowest: compound 2; then compounds 1 and 3 (each within the scatter of the next); then compound 4.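

In this assay, for the compounds shown here, phenyl in place of ethyl on this aromatic carbon gives a 3.8-fold higher number from compound 1 to compound 4 (0.58 log units; beyond the scatter), the only step that changes a single substituent while the rest of the aryl ring stays the same. This position therefore responds to that exchange alone, and the direction here is toward a higher number. No data at hand account for this shift.

Open, on these data alone, is how a cyclohexyl ring, a pyridyl ring or a longer chain such as propyl would read on this carbon. That leaves unsettled whether the aromatic ring itself or simply the added carbons go with the higher number.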